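Methyl for fluoro on the fused ring of compound 3

The source may hold more compounds than are shown below. What is called first, only, known or untested is meant among the compounds shown, and "the series" means these compounds.

Compound 3 `O=C(Nc1nc2ccc(F)cc2s1)c1cn(-c2ccccc2)nc1-c1ccc(F)cc1` gives 16700 nM in an ADME assay on HEK-293T cells (Homo sapiens) for cytotoxicity, read by MTT assay, with a stated time of 72 h (a higher number here means a weaker inhibitor, a lower number a stronger inhibitor), the lowest of the two numbers shown, and sits close to compound 1 `O=C(Nc1nc2ccc(F)cc2s1)c1cn(-c2ccccc2)nc1-c1ccccc1` at 17600 nM; the two lie within the scatter. Compound 2 `Cc1ccc2nc(NC(=O)c3cn(-c4ccccc4)nc3-c3ccccc3)sc2c1` gives only a limit, > 50000 nM, that is the limit of > 50000 nM in this assay, at which 1 of the 3 values shown sits. Compound 4 `Cc1ccc2nc(NC(=O)c3cn(-c4ccccc4)nc3-c3ccc(F)cc3)sc2c1` carries the change (methyl in place of fluoro on an aromatic carbon). The same swap has been measured once, as an at least 2.8-fold higher number from compound 1 to compound 2 (0.45 log units; beyond the scatter), ending at the limit. The step of a 1.1-fold lower number from compound 1 to compound 3 (0.02 log units; within the scatter) lay within the scatter, so the swap on the fused ring is expected to set the outcome here as well. Compound 4 is therefore expected to give 50000 nM (range 25000 nM to 100000 nM). The step of a 3.0-fold higher number from compound 3 to compound 4 (0.48 log units; beyond the scatter) is expected to be a rise that may again end at the limit.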

Compound 4, half-maximal inhibitory concentration: > 50000 nM
Compound 4: only a limit was reported (the forecaster's own chance of this, stated with the estimate: 60%); the middle value lies on the limit itself.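

In this assay, 6-methyl-1,3-benzothiazol-2-yl in place of 6-fluoro-1,3-benzothiazol-2-yl gives an at least 2.9-fold higher number from compound 3 to compound 4 (0.47 log units; beyond the scatter), so the swap at this position now moves the number beyond the scatter on a second core. The direction holds on both cores shown: the same change on two cores in this assay, an at least 2.8-fold higher number (0.45 log units; beyond the scatter) from compound 1 to compound 2 and an at least 2.9-fold higher number (0.47 log units; beyond the scatter) from compound 3 to compound 4; the limit leaves it open whether they differ. Compound 4 gives only a limit, > 50000 nM.

On these data alone, the step from compound 2 to compound 4 cannot be read, as both values are limits, and the true size of the methyl effect stays open on either core. Also open, as far as these compounds go, is where an amine or a methoxy group at this position would fall relative to the fluoro and methyl compounds.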